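Compound 3 to compound 4: carboxy replaced by (dimethylamino)methyl

The compounds below may be only part of what the source reports. "The series", "measured", "known", "first", "only" and "open" are said of these compounds alone.

In a functional assay on SMMC-7721 cells (Homo sapiens) for antiproliferative activity, read by MTT assay, with a stated time of 48 h (a lower number here means a stronger inhibitor, a higher number a weaker inhibitor), compound 1 (`CC(=O)OC/C1=C/C[C@](C)(CCC=C(C)C)/C=C/[C@@H](OC(=O)C=C(C)C)[C@](C)(O)/C=C/C1=O`) gives 2950 nM and compound 2 (`C=C1/C=C/C(=O)/C(CO)=C\C[C@](C)(CCC=C(C)C)/C=C/[C@H]1OC(=O)C=C(C)C`) gives 4300 nM. Compound 3 (`CC(C)=CCC[C@]1(C)/C=C/[C@@H](OC(=O)C=C(C)C)[C@](C)(O)/C=C/C(=O)/C(C(=O)O)=C\C1`) gives > 10000 nM in this assay, which is a limit of the assay and not a number.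

Compound 4 (`CC(C)=CCC[C@]1(C)/C=C/[C@@H](OC(=O)C=C(C)C)[C@](C)(O)/C=C/C(=O)/C(CN(C)C)=C\C1`) carries (dimethylamino)methyl in place of carboxy on a double-bonded ring carbon.

Within the data shown here, one measured step bears on this change. It is an at least 3.3-fold higher number from compound 1 to compound 3 (0.53 log units; beyond the scatter), with carboxy in place of acetoxymethyl on that same double-bonded ring carbon. Compound 4 loses the carboxy again, so a move to a lower number is expected, and the step just given sets the likely scale. Among the measured compounds shown here, no measured compound carries (dimethylamino)methyl, which leaves the size of the move uncertain, and another reading at the limit cannot be ruled out.

Expected in this assay is an at least 2.0-fold lower number from compound 3 to compound 4 (0.30 log units; that floor lies within the scatter). For compound 4 the estimate is 5000 nM, with an expected range from 1800 nM to 10000 nM.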

Compound 4, half-maximal inhibitory concentration: 820 nM
Beside the measured number, compound 4's estimate is 6.1-fold (0.79 log units) above it, outside the stated range (below it).
By their numbers in this assay, from the lowest: compound 4; then compounds 1 and 2 (each within the scatter of the next). At a limit, above all of these: compound 3.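

In this assay, the double-bonded ring carbon no longer looks like a place where change only pushes the number up: (dimethylamino)methyl in place of carboxy gives an at least 12-fold lower number from compound 3 to compound 4 (1.08 log units; beyond the scatter). The comparison with the acetoxymethyl group shows a shift in the other direction from the earlier step, with dimethylamino in place of acetoxy on the saturated chain carbon giving a 3.6-fold lower number from compound 1 to compound 4 (0.56 log units; beyond the scatter), so this position can also improve on compound 1 and not only fall short of it. Compound 3 sits at a limit of the assay and not at a number, so the first step gives only a floor, and its true size remains unknown: the limit of > 10000 nM in this assay, at which 1 of the 4 values shown sits.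

On these data alone, it remains open whether the gain requires the dimethylamino group in particular, and an aminomethyl, pyrrolidin-1-ylmethyl or morpholin-4-ylmethyl group on the same carbon would test this. A longer chain carrying the dimethylamino group, or an ester or amide in place of the carboxy group, would show how far the change tolerates other groups at this position.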